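The source may hold more compounds than are shown below. What is called first, only, known or untested is meant among the compounds shown, and "the series" means these compounds.

Of the compounds shown here, three that share one core have been tested in a functional assay on HepG2 cells for inhibition of squalene monooxygenase (Homo sapiens); a lower number here means a stronger inhibitor, a higher number a weaker inhibitor. Compound 1 `CCN(C/C=C/C#CC(C)(C)C)Cc1cccc(OCCN(C)S(=O)(=O)c2ccc(Br)cc2)c1` gives 330 nM. Compound 2 `CCN(C/C=C/C#CC(C)(C)C)Cc1cccc(OCCN(C)S(=O)(=O)c2ccc(C#N)cc2)c1` gives 200 nM, and compound 3 `CCN(C/C=C/C#CC(C)(C)C)Cc1cccc(OCCN(C)S(=O)(=O)c2nccs2)c1` gives 170 nM. The steps between them are small: a 1.7-fold lower number from compound 1 to compound 2 (0.22 log units; within the scatter) and a 1.9-fold lower number from compound 1 to compound 3 (0.29 log units; within the scatter), while a 1.2-fold lower number from compound 2 to compound 3 (0.07 log units; within the scatter). Compound 3 therefore has the lowest of the three numbers, but each of the other two lies within the scatter of it, so no ranking among the three can be drawn.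

Compound 4 `CCN(C/C=C/C#CC(C)(C)C)Cc1cccc(OCCN(CC)S(=O)(=O)c2cccs2)c1` has not yet been measured in this assay. Compared with compound 3 it carries a group of 11 heavy atoms (6 carbon, 1 nitrogen, 2 oxygen, 2 sulfur; one five-membered aromatic ring with 1 hetero atom) in place of a group of 10 heavy atoms (4 carbon, 2 nitrogen, 2 oxygen, 2 sulfur; one five-membered aromatic ring with 2 hetero atoms), on a saturated chain carbon, two bonds along the chain from an oxygen on an aromatic ring. The measured steps that come closest to this change are those that swapped the group on the sulfonyl sulfur, namely a 1.9-fold lower number from compound 1 to compound 3 (0.29 log units; within the scatter) and a 1.2-fold lower number from compound 2 to compound 3 (0.07 log units; within the scatter), and both stayed within the scatter. Nothing measured speaks to the other part of the change, the group on the nitrogen beside the sulfonyl sulfur. On that basis no step beyond the scatter is expected, and the estimate for compound 4 is 220 nM, with a range from 80 nM to 600 nM, which amounts to an expected 1.3-fold higher number from compound 3 to compound 4 (0.11 log units; within the scatter).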

Compound 4, half-maximal inhibitory concentration: 90 nM
Compound 4: middle estimate off by 2.4-fold (0.39 log units), on the high side; low and high end bracket the measured number.
By their numbers in this assay, from the lowest: compounds 4, 3, 2 and 1 (each within the scatter of the next, the first and the last beyond it).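

For the compounds shown here, compound 4 is the first compound here to alter the part of the molecule on a saturated chain carbon, two bonds along the chain from an oxygen on an aromatic ring, rather than only the group on the sulfonyl sulfur. In this assay, bringing in ethyl((thiophen-2-yl)sulfonyl)amino gives a 1.9-fold lower number from compound 3 to compound 4 (0.28 log units; within the scatter), so this position accepts an ethyl group on the nitrogen together with a five-membered aromatic ring with 1 hetero atom in place of one with 2, with no step beyond the scatter. No measured data bear on why the two compounds read so alike, and none gives a cause for this result.

Both parts of the group differ at once, so the compounds shown cannot tell what the ethyl group and the thiophene ring each contribute, or whether one offsets the other; that would take a compound pairing the thiophene ring with the methyl group on the nitrogen, or the thiazole ring with the ethyl group. Also open, on these data alone, is how a longer chain such as propyl on that nitrogen, or an amine on the five-membered ring, would read.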